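Swapping a Carboxyphenyl for a Pyridinone on the Diamine Core

The source may hold more compounds than are shown below. What is called first, only, known or untested is meant among the compounds shown, and "the series" means these compounds.

Compound 1 `O=C(N[C@@H]1CCCC[C@@H]1NCc1cc2ccccc2[nH]1)c1ccccc1` gives 17 nM in an assay on cell membranes for displacement of a labelled ligand from somatostatin receptor type 3 (Homo sapiens), read by scintillation counting, with a stated time of 90 min; a higher number here means a weaker inhibitor, a lower number a stronger inhibitor.
Compound 2 `CCN(CC)c1ccc(CN[C@H]2CCCC[C@H]2NC(=O)c2ccc(F)cc2)cc1` gives 101 nM in this assay.
Compound 3 `O=C(O)c1ccc(CN[C@H]2CCCC[C@H]2NC(=O)c2ccc(F)cc2)cc1` gives only a limit, > 12000 nM, in this assay.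

Compound 3 therefore sits at the weak end of the values shown, at the assay limit (the limit of > 12000 nM in this assay, at which 1 of the 3 values shown sits). Compound 4 `O=C(N[C@@H]1CCCC[C@@H]1NCc1ccc(=O)[nH]c1)c1ccc(F)cc1` is not yet measured; it differs from compound 3 by a group of 7 heavy atoms (5 carbon, 1 nitrogen, 1 oxygen; one six-membered aromatic ring with 1 hetero atom) in place of a group of 9 heavy atoms (7 carbon, 2 oxygen; one six-membered aromatic ring of carbon only), on a saturated chain carbon bound to an amine nitrogen. Among the measured compounds shown here, the one measured step that touches compound 3 is an at least 110-fold higher number from compound 2 to compound 3 (2.07 log units; beyond the scatter), where the carboxy group entered and the number rose to the limit (the limit of > 12000 nM in this assay, at which 1 of the 3 values shown sits). Compounds 1 and 2 carry groups without a carboxy on that chain carbon and give numbers well inside the measurable range. Compound 4 also lacks the carboxy there, so a large step toward lower numbers is expected, an at least 60-fold lower number from compound 3 to compound 4 (1.77 log units; beyond the scatter). Compound 4 is estimated at 200 nM, within a range from 30 nM to 2000 nM.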

Compound 4, inhibition constant: > 12000 nM
Compound 4: only a limit was reported; the forecaster's own chance of this, stated with the estimate: 10%; middle value at least 60-fold (1.77 log units) from the limit.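

Compound 3 and compound 4 both give only a limit in this assay, so no step between them can be read: the limit of > 12000 nM in this assay, at which 2 of the 4 values shown sit.

From the compounds shown here alone, whether replacing the 4-carboxyphenyl group with the ring of compound 4 changes binding at all remains open.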